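Swapping a Ring for an Open Chain on the Core

This account rests on a few compounds, and the source may have more. Where it says the series, first, only, none or still open, it means among the compounds named here.

Compound 1 `CN(C)CCCNc1c(C(=O)NCc2ccc(F)cc2)nc(Br)c2cccnc12` measured at 7000 nM
Compound 2 `O=C(NCc1ccc(F)cc1)c1nc(Br)c2cccnc2c1NCCO` recorded as "not determined" (no result reported)
Compound 3 `O=C(NCc1ccc(F)cc1)c1nc(Br)c2cccnc2c1N1CCNCC1` measured at 7000 nM
Compound 4 `NCCCCCCNc1c(C(=O)NCc2ccc(F)cc2)nc(Br)c2cccnc12` not yet measured

In a functional assay on MCF7 cells (Homo sapiens) for cytotoxicity, read by MTT assay, with a stated time of 72 h (a higher number here means a weaker inhibitor, a lower number a stronger inhibitor), compound 3 stands at 7000 nM and sits level with compound 1 at 7000 nM on the digits given. For compound 2 the result reads "not determined" (no result reported) and so it offers no comparison. The move to compound 4 puts (6-aminohexyl)amino in place of piperazin-1-yl ((6-aminohexyl)amino in place of piperazin-1-yl on an aromatic carbon) on an aromatic carbon para to a bromo group. For the measured compounds named here, only one measured step bears on this change. It shows no change at the digits printed from compound 1 to compound 3 (within the scatter) with piperazin-1-yl in place of (3-(dimethylamino)propyl)amino on an aromatic carbon. One step is thin evidence, but there an open chain and the ring gave matching values. In this assay no shift beyond the scatter is therefore expected in either direction, and the expected step is a 1.2-fold lower number from compound 3 to compound 4 (0.07 log units; within the scatter) on present data. Going by the values given here, the (6-aminohexyl)amino chain itself has no measured counterpart, so the range stays wide. For compound 4 the estimated value is 6000 nM with an expected range from 2000 nM to 15000 nM in this assay.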

Compound 4, half-maximal inhibitory concentration: 2000 nM
The estimate for compound 4 lay 3.0-fold (0.48 log units) above the measured number; measured number inside the range.
By their numbers in this assay, from the lowest: compound 4; then compounds 1 and 3 (each within the scatter of the next).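

In this assay the swap of piperazin-1-yl for (6-aminohexyl)amino gives a 3.5-fold lower number from compound 3 to compound 4 (0.54 log units; beyond the scatter) and the comparison with the other open chain gives a 3.5-fold lower number from compound 1 to compound 4 (0.54 log units; beyond the scatter) on the same aromatic carbon. The earlier pair had shown no difference between a ring and an open chain here, so this position does respond to the group it carries, and an open chain does not by itself match the ring. Nothing measured here gives a reason for this step.

The compounds shown leave open whether the length of the chain or the amine at its end matters, as the two change together here. A (6-hydroxyhexyl)amino chain, with a hydroxyl in place of that amine, or a shorter (4-aminobutyl)amino chain would pull the two apart.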